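A few compounds are considered here, and "the series" means these few. Any claim that something is new, unique, unknown or untested is made for them only; others in the source may bear on it.

Compound 1 `CNC(=O)CC1CCc2cc(OC)c(OC)cc21`: 30%
Compound 2 `CCCCNC(=O)CC1CCc2cc(OC)c(OC)cc21`: 24%
Compound 3 `CCCCCNC(=O)CC1CCc2cc(OC)c(OC)cc21`: 34%

In a functional assay on the whole organism (strain Wistar) for inhibition, with Rattus norvegicus as the target, read by paw edema, with stated times of 60 min and 2 h, at a dose of 100 mg/kg by the oral route (on this read-out lower numbers stand for less inhibition and higher numbers for more inhibition at the one dose given (going by the name of the read-out)), compound 3 gives the highest of the three numbers, yet every gap to the others lies within the scatter: a number 4 percentage points higher from compound 1 to compound 3 (within the scatter) and a number 10 percentage points higher from compound 2 to compound 3 (within the scatter), as does a number 6 percentage points lower from compound 1 to compound 2 (within the scatter). Compound 4 `COc1cc2c(cc1OC)C(CC(=O)N1CCOCC1)CC2` differs from compound 3 by morpholin-4-yl in place of pentylamino on a carbonyl carbon. Among the compounds with values here, no measured step touches this kind of change; all three vary only the chain on the amide-type nitrogen, and none moves the read-out beyond the scatter, so they give no direction for exchanging the hydrogen-bond donor for a ring with a hydrogen-bond acceptor. The expected step is therefore a number 4 percentage points lower from compound 3 to compound 4 (within the scatter), with a wide range. For compound 4 the estimate is 30%, between 12% and 48%.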

Compound 4, a percentage reported as inhibition, in the whole organism at one dose (the size of the read-out at that dose, not a potency): 14%
Estimate against measurement, compound 4: 16 percentage points above; measured number inside the range.
By their numbers in this assay, from the lowest: compounds 4, 2, 1 and 3 (each within the scatter of the next, the first and the last beyond it).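

Within the data shown here, at the carbonyl carbon, morpholin-4-yl in place of an open amino chain gives the only steps beyond the scatter in this assay: a number 20 percentage points lower from compound 3 to compound 4 (beyond the scatter) and a number 16 percentage points lower from compound 1 to compound 4 (beyond the scatter). Against butylamino the same exchange gives a number 10 percentage points lower from compound 2 to compound 4 (within the scatter), so the fall is not established against all three amides. Nothing available bears on the reason for these steps.

Still open, from the compounds shown here alone, is whether the ring, its oxygen or the absent amide hydrogen goes with the lower numbers. Piperidin-1-yl or dimethylamino on the same carbonyl carbon would separate these.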